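Swapping Bromine for Iodine on the Benzamide Ring

This account rests on a few compounds, and the source may have more. Where it says the series, first, only, none or still open, it means among the compounds named here.

Compound 3 `NC(=O)c1c(NC(=O)c2ccccc2Br)sc2c1CCN(C(=S)Nc1ccccc1Br)C2` gives 17600 nM in a functional assay on HL-60 cells (Homo sapiens) for antiproliferative activity, with a stated time of 24 h (a higher number here means a weaker inhibitor, a lower number a stronger inhibitor), the highest of the three numbers measured, though its gap to compound 1 lies within the usual scatter while its gap to compound 2 lies beyond it. Compound 1 `NC(=O)c1c(NC(=O)c2ccccc2Cl)sc2c1CCN(C(=S)Nc1ccccc1Br)C2` gives 9090 nM, and compound 2 `NC(=O)c1c(NC(=O)c2ccccc2I)sc2c1CCN(C(=S)Nc1ccccc1Cl)C2` gives 8560 nM. Among the measured compounds shown here, only one measured step changes a single place: a 1.9-fold higher number from compound 1 to compound 3 (0.29 log units; within the scatter), a halogen swap on the same ring that compound 4 alters. Compound 4 `NC(=O)c1c(NC(=O)c2ccccc2I)sc2c1CCN(C(=S)Nc1ccccc1Br)C2` differs from compound 3 by iodo in place of bromo on an aromatic carbon. That earlier halogen swap stayed within the scatter, and compound 2, which also carries iodo on this ring, sits close to compound 1, so no step beyond the scatter is expected here. The estimate for compound 4 is 13000 nM, between 6000 nM and 30000 nM, an expected step of a 1.4-fold lower number from compound 3 to compound 4 (0.13 log units; within the scatter).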

Compound 4, half-maximal inhibitory concentration: 18900 nM
The estimate for compound 4 lay 1.5-fold (0.16 log units) below the measured number, within the range that was stated.
By their numbers in this assay, from the lowest: compounds 2, 1, 3 and 4 (each within the scatter of the next, the first and the last beyond it).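

In this assay, iodo in place of bromo at this position changes almost nothing, a 1.1-fold higher number from compound 3 to compound 4 (0.03 log units; within the scatter), so the two halogens cannot be told apart here. Iodo in place of chloro at the same position gives a 2.1-fold higher number from compound 1 to compound 4 (0.32 log units; beyond the scatter), a modest weakening beyond the scatter, which the bromo compound alone did not show. Bromo in place of chloro elsewhere in the molecule gives a 2.2-fold higher number from compound 2 to compound 4 (0.34 log units; beyond the scatter), and this matches the same swap at this position: the same change on two cores in this assay, a 1.9-fold higher number (0.29 log units; within the scatter) from compound 1 to compound 3 and a 2.2-fold higher number (0.34 log units; beyond the scatter) from compound 2 to compound 4, 1.1-fold (0.06 log units) apart, within the scatter of two such steps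

Still open, going by these compounds, is whether a non-halogen group here, such as an amine or a methoxy, would shift the number, and what a plain hydrogen would give.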